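The source may hold more compounds than are shown below. What is called first, only, known or untested is meant among the compounds shown, and "the series" means these compounds.

Compound 1 `COc1cc(OC)c(-c2coc3cc(OCc4ccccc4C(F)(F)F)ccc3c2=O)cc1OC`: 4760 nM
Compound 2 `COc1cc(OC)c(-c2coc3cc(OCc4ccccc4C#N)ccc3c2=O)cc1OC`: > 10000 nM

Both values come from a functional assay on HCT-116 cells (Homo sapiens) for antiproliferative activity, read by MTT assay, with a stated time of 24 h; a higher number here means a weaker inhibitor, a lower number a stronger inhibitor. Compound 2 stands at > 10000 nM, which is a limit of the assay and not a number.

Compound 3 `COc1cc(OC)c(-c2coc3cc(OCc4cccc(C(F)(F)F)c4)ccc3c2=O)cc1OC` has not yet been measured. It differs from compound 2 in one place: 3-(trifluoromethyl)phenyl in place of 2-cyanophenyl on a saturated chain carbon bound to an oxygen on an aromatic ring. In words, 3-(trifluoromethyl)phenyl takes the place of 2-cyanophenyl.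

Within the data shown here, only one measured step bears on this change: an at least 2.1-fold higher number from compound 1 to compound 2 (0.32 log units; beyond the scatter). There, cyano replaced trifluoromethyl. Among the measured compounds shown here, compound 3 brings trifluoromethyl back, but as 3-(trifluoromethyl)phenyl, a group with no measured value so far, so that step is only a loose guide. Going by it, a lower number is expected for compound 3, in a step of modest size. The expected change is an at least 1.8-fold lower number from compound 2 to compound 3 (0.25 log units; that floor lies within the scatter). For compound 3 the estimate is 5500 nM, with an expected range of 2000 nM to 12000 nM.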

Compound 3, half-maximal inhibitory concentration: 3400 nM
The estimate for compound 3 lay 1.6-fold (0.21 log units) above the measured number; measured number inside the range.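

In this assay, replacing 2-cyanophenyl with 3-(trifluoromethyl)phenyl gives an at least 2.9-fold lower number from compound 2 to compound 3 (0.46 log units; beyond the scatter). Set against 2-(trifluoromethyl)phenyl, the 3-(trifluoromethyl)phenyl group gives a 1.4-fold lower number from compound 1 to compound 3 (0.15 log units; within the scatter), so these two trifluoromethyl-bearing groups cannot be told apart in this measurement. Compound 2 carries a limit of the assay and not a number, so the full size of its step to the new compound stays unknown: the limit of > 10000 nM in this assay, at which 1 of the 3 values shown sits.

The compounds shown leave open whether 3-cyanophenyl would behave like 3-(trifluoromethyl)phenyl or like 2-cyanophenyl, so the effect of the nitrile cannot yet be separated from the effect of where it sits. They also say nothing about a benzyl group carrying an amine or a carboxylic acid, or about a longer chain linking the phenyl ring to the oxygen.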